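Shortening the Ether Linker and Expected Clearance

The source may hold more compounds than are shown below. What is called first, only, known or untested is meant among the compounds shown, and "the series" means these compounds.

Compound 1 `c1cc([C@H]2CC[C@]3(CC2)OOC2(O3)C3CC4CC(C3)CC2C4)ccc1OCC1CCNCC1` was tested in an ADME assay on microsomes from liver (Homo sapiens) for metabolic stability, read by LC-MS, tested at 1 uM; on this read-out higher numbers stand for fast clearance and lower numbers for slow clearance. In this assay compound 1 gives < 7 mL.min-1.g-1, which is a limit of the assay rather than a number. Two related compounds share its core. Compound 2 `NCCCOc1ccc([C@H]2CC[C@]3(CC2)OOC2(O3)C3CC4CC(C3)CC2C4)cc1` gives < 7 mL.min-1.g-1 in this assay, again a limit of the assay. Compound 3 `NCCOCCOc1ccc([C@H]2CC[C@]3(CC2)OOC2(O3)C3CC4CC(C3)CC2C4)cc1` gives < 7 mL.min-1.g-1 in this assay, also a limit of the assay. The steps among these three, a step that the two limits leave unreadable from compound 1 to compound 2, a step that the two limits leave unreadable from compound 1 to compound 3 and a step that the two limits leave unreadable from compound 2 to compound 3, therefore cannot be sized; all that is known is the limit of < 7 mL.min-1.g-1 in this assay, at which 3 of the 3 values shown sit.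

Compound 4 `c1cc([C@H]2CC[C@]3(CC2)OOC2(O3)C3CC4CC(C3)CC2C4)ccc1OC1CCNCC1` has not yet been measured. It differs from compound 1 in one place: piperidin-4-yl in place of (piperidin-4-yl)methyl on an oxygen on an aromatic ring. Every measured step concerns the group carried on the aromatic oxygen, yet each is unreadable, so no direction or size can be drawn from them. Because the limit of < 7 mL.min-1.g-1 in this assay, at which 3 of the 3 values shown sit, holds for every measured compound, compound 4 is expected to sit there as well, an expected step that the limit leaves unreadable from compound 1 to compound 4. Compound 4 is estimated at 4 mL.min-1.g-1, within 2 mL.min-1.g-1 to 9 mL.min-1.g-1.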

Compound 4, intrinsic clearance in microsomes: 15 mL.min-1.g-1
Compound 4: the middle estimate sits 3.8-fold (0.57 log units) below what was measured; the measured number lies above the stated range.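

Setting piperidin-4-yl in place of (piperidin-4-yl)methyl on the oxygen on the aromatic ring gives an at least 2.1-fold higher number from compound 1 to compound 4 (0.33 log units; beyond the scatter), so a change at this position can be read in this assay. Piperidin-4-yl also stands apart from the open chains on the same oxygen, with an at least 2.1-fold higher number from compound 2 to compound 4 (0.33 log units; beyond the scatter) for 3-aminopropyl and an at least 2.1-fold higher number from compound 3 to compound 4 (0.33 log units; beyond the scatter) for 2-(2-aminoethoxy)ethyl. Compound 4 is thus the only compound shown with a readable number, and the shared limit no longer covers the whole set: the limit of < 7 mL.min-1.g-1 in this assay, at which 3 of the 4 values shown sit.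

On these data alone, the steps among compound 1, compound 2 and compound 3 still cannot be read, and the true size of each new step stays unknown. Also open, as far as these compounds go, is whether a smaller amine ring on the same oxygen, such as pyrrolidin-3-yl or azetidin-3-yl, would behave like piperidin-4-yl.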